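Methoxy to hydroxy in a small cytotoxicity series

This account rests on a few compounds, and the source may have more. Where it says the series, first, only, none or still open, it means among the compounds named here.

Three compounds measured so far in a functional assay on SH-SY5Y cells (Homo sapiens) for cytotoxicity, read by MTT assay, with a stated time of 48 h; on this read-out lower numbers stand for stronger inhibition and higher numbers for weaker inhibition
- compound 1 `COc1cc(/C=C/C(=O)/C=C/c2nc3c(C)cccc3n2C)ccc1O` gives 1000 nM
- compound 2 `COc1cc(/C=C/C(=O)/C=C/c2nc3c(C)c(C)ccc3n2C)ccc1O` gives 19000 nM
- compound 3 `COc1ccc2c(c1)nc(/C=C/C(=O)/C=C/c1ccc(O)c(OC)c1)n2C` gives 4800 nM

In this assay compound 3 at 4800 nM stands second highest of the three numbers, below compound 2 and above compound 1, with both gaps beyond the scatter.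

Compound 4 `COc1cc(/C=C/C(=O)/C=C/c2nc3cc(O)ccc3n2C)ccc1O` is still unmeasured. Its structure differs from that of compound 3 by hydrogen in place of methyl on an oxygen on an aromatic ring, which reads as methoxy to hydroxy, hydrogen in place of methyl on an oxygen on an aromatic ring.

Within the data shown here, only one measured step connects two compounds differing in one place: a 19-fold higher number from compound 1 to compound 2 (1.28 log units; beyond the scatter), with methyl in place of hydrogen on an aromatic carbon. Among the measured compounds shown here, that large step involves a different change, so it sets no direction for methoxy to hydroxy, and no measured pair shows this change directly. The expected range stays wide because a 19-fold higher number from compound 1 to compound 2 (1.28 log units; beyond the scatter) came from a single methyl.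

With no direction favoured, no shift beyond the scatter is expected as the central case, and a 1.1-fold lower number from compound 3 to compound 4 (0.03 log units; within the scatter) is the estimated step. Compound 4 is expected at 4500 nM in this assay, with an estimated range of 1100 nM to 18000 nM for repeat measurements.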

Compound 4, half-maximal inhibitory concentration: 4800 nM
Estimate against measurement, compound 4: 1.1-fold (0.03 log units) below, within the range that was stated.
By their numbers in this assay, from the lowest: compound 1; then compounds 3 and 4 (each within the scatter of the next); then compound 2.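

In this assay, among these compounds, hydrogen in place of methyl on an oxygen on an aromatic ring gives no change at the digits printed from compound 3 to compound 4 (within the scatter), so this series now has a direct reading of methoxy to hydroxy, which no earlier pair supplied. Among the compounds shown here, at this place, compound 3 and compound 4 cannot be told apart in this assay, whereas the only earlier step, a different change at a different place, was a 19-fold higher number from compound 1 to compound 2 (1.28 log units; beyond the scatter); a single small exchange on the shared core therefore need not produce a step of that size. No measurement at hand accounts for the agreement between compound 3 and compound 4.

As far as these compounds go, one pair describes this change at one place only, so it remains open whether methoxy to hydroxy would read the same elsewhere on the shared core, or whether the result extends beyond this assay. From the compounds shown here alone, it is also open how the number would respond to an ethoxy group or a longer chain on the same oxygen, or to an amine or a carboxylic acid in place of the hydroxy group.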